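The source may hold more compounds than are shown below. What is called first, only, known or untested is meant among the compounds shown, and "the series" means these compounds.

Compound 3 `Clc1ccc(COc2ccc(Nc3ncnc4c3cnn4-c3ccc(Cl)cc3)cc2)cc1` stands at a limit in a functional assay on MCF7 cells (Homo sapiens) for cytotoxicity, read by sulforhodamine B assay, with a stated time of 72 h (a lower number here means a stronger inhibitor, a higher number a weaker inhibitor), and has no number there: it reads > 100000 nM as a limit of the assay. That reading is the limit of > 100000 nM in this assay, at which 1 of the 3 values shown sits, in this small set. In this assay compound 1 `Cc1ccccc1NC(=O)Nc1ccc(Nc2ncnc3c2cnn3-c2ccc(Cl)cc2)cc1` gives 3150 nM and compound 2 `O=C(Nc1ccc(Nc2ncnc3c2cnn3-c2ccc(Cl)cc2)cc1)Nc1ccccc1Cl` gives 9050 nM there, which is a 2.9-fold higher number from compound 1 to compound 2 (0.46 log units; beyond the scatter) and only a modest step. The steps that bear most on what follows are an at least 31-fold higher number from compound 1 to compound 3 (1.50 log units; beyond the scatter) and an at least 11-fold higher number from compound 2 to compound 3 (1.04 log units; beyond the scatter) and both are large. The move to compound 4 `O=C(NC1CCCCC1)c1ccc(Nc2ncnc3c2cnn3-c2ccc(Cl)cc2)cc1` puts cyclohexylcarbamoyl in place of (4-chlorobenzyl)oxy on an aromatic carbon and so removes the group that marks compound 3 in those large steps. Compound 4 shares a carbamoyl unit with compound 1 at 3150 nM but lacks its full ((2-methylphenyl)carbamoyl)amino group, so a sizeable step to a lower number is expected, stopping short of that value. The estimated change is an at least 5.0-fold lower number from compound 3 to compound 4 (0.69 log units; beyond the scatter) in size and direction alike. For compound 4 the expected value is 20000 nM with an estimated range from 4000 nM to 100000 nM while the measurement stands open.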

Compound 4, half-maximal inhibitory concentration: > 100000 nM
Compound 4 ended at the assay's limit; the forecaster's own chance of this, stated with the estimate: 25%; middle value at least 5.0-fold (0.69 log units) away from the limit.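

In this assay compound 4 stands at a limit of the assay, as compound 3 does, so the step between them cannot be read: the limit of > 100000 nM in this assay, at which 2 of the 4 values shown sit.

The cyclohexylcarbamoyl group, with its hydrogen-bond donor and non-aromatic ring, still leaves a gap to both compounds with a readable value, with an at least 11-fold higher number from compound 2 to compound 4 (1.04 log units; beyond the scatter) and an at least 31-fold higher number from compound 1 to compound 4 (1.50 log units; beyond the scatter). Among these four compounds, then, a carbamoyl unit on this aromatic carbon does not by itself give a readable value; only the ((2-methylphenyl)carbamoyl)amino and ((2-chlorophenyl)carbamoyl)amino groups do.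

The compounds shown leave open whether the readable values depend on the amino link to the carbonyl, on the aromatic ring at the end of the group, or on both. A (cyclohexylcarbamoyl)amino group or a phenylcarbamoyl group at this position would separate the two.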